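The source may hold more compounds than are shown below. What is called first, only, known or untested is meant among the compounds shown, and "the series" means these compounds.

Compound 3 `C=Cc1csc(CN[C@@H]2C[C@H]3C[C@@H]([C@H]2C)C3(C)C)c1` gives 6250 nM in an ADME assay on MDCK cells (Canis lupus familiaris) for cytotoxicity, read by microscopy, with a stated time of 48 h; on this read-out lower numbers stand for higher toxicity in this test and higher numbers for lower toxicity in this test. Of the two numbers shown it sits at the low end, though the gap to compound 1 `CCCCc1csc(CN[C@@H]2C[C@H]3C[C@@H]([C@H]2C)C3(C)C)c1`, which gives 12500 nM, is within the scatter. Compound 2 `C[C@H]1[C@H](NCc2cncnc2)C[C@H]2C[C@@H]1C2(C)C` yields not a number but a limit in this assay, > 100000 nM, as recorded by the limit of > 100000 nM in this assay, at which 1 of the 3 values shown sits. Compound 4 `Cc1csc(CN[C@@H]2C[C@H]3C[C@@H]([C@H]2C)C3(C)C)c1` is reached from compound 3 by methyl in place of vinyl on an aromatic carbon. Within the data shown here, the one measured step that bears on this position is a 2.0-fold lower number from compound 1 to compound 3 (0.30 log units; within the scatter), so a change of the group on that aromatic carbon has so far moved the number only within the scatter. The same is expected here, namely a 1.4-fold higher number from compound 3 to compound 4 (0.16 log units; within the scatter). Compound 4 is therefore estimated at 9000 nM, with a range from 3500 nM to 30000 nM.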

Compound 4, minimum cytotoxic concentration: 12500 nM
For compound 4 the middle estimate is 1.4-fold (0.14 log units) below the measured one; the range from low to high includes it.
By their numbers in this assay, from the lowest: compounds 3, 1 and 4 (each within the scatter of the next). At a limit, above all of these: compound 2.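

In this assay, methyl on this aromatic carbon gives a 2.0-fold higher number from compound 3 to compound 4 (0.30 log units; within the scatter), and the change from the butyl of compound 1 gives no change at the digits printed from compound 1 to compound 4 (within the scatter), so butyl, vinyl and methyl are not told apart here. Only 4-methylthiophen-2-yl in place of pyrimidin-5-yl goes beyond the scatter, with an at least 8.0-fold lower number from compound 2 to compound 4 (0.90 log units; beyond the scatter). Compound 2 gives a limit and not a number: the limit of > 100000 nM in this assay, at which 1 of the 4 values shown sits. Open, from the compounds shown here alone, is whether an amine or a carboxylic acid on that aromatic carbon would move the number beyond the scatter.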